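Second trifluoromethyl on the linker-extended urea

A few compounds are considered here, and "the series" means these few. Any claim that something is new, unique, unknown or untested is made for them only; others in the source may bear on it.

Measured compounds:
compound 1 `COc1cc(NC(C)CCCNC(=O)Nc2cc(C(F)(F)F)cc(C(F)(F)F)c2)c2ncccc2c1` — 3500 nM in a functional assay on L1210 cells (Mus musculus) for inhibition, read by MTT assay, with a stated time of 72 h; on this read-out lower numbers stand for stronger inhibition and higher numbers for weaker inhibition
compound 2 `COc1cc(NC(C)CCCNC(=O)Nc2cccc(C(F)(F)F)c2)c2ncccc2c1` — 9200 nM
compound 3 `COc1cc(NC(C)CCCNC(=O)NNC(=O)Nc2cccc(C(F)(F)F)c2)c2ncccc2c1` — 4000 nM

Between compound 2 and compound 1 the only change is trifluoromethyl in place of hydrogen on an aromatic carbon, and it gives a 2.6-fold lower number from compound 2 to compound 1 (0.42 log units; beyond the scatter). The difference between the core of compound 3 and the core of compound 2 is not broken down here; compound 3 gives a number within the scatter of compound 1 and a higher one than compound 2.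

Compound 4 `COc1cc(NC(C)CCCNC(=O)NNC(=O)Nc2cc(C(F)(F)F)cc(C(F)(F)F)c2)c2ncccc2c1` is not yet measured. It differs from compound 3 by trifluoromethyl in place of hydrogen on an aromatic carbon, the same change as from compound 2 to compound 1, at a place described in the same words. The step is expected to be a 2.4-fold lower number from compound 3 to compound 4 (0.37 log units; beyond the scatter) in this assay, beside a 2.6-fold lower number from compound 2 to compound 1 (0.42 log units; beyond the scatter), resting on that single earlier pair. Compound 4 is therefore estimated at 1700 nM, expected between 800 nM and 4000 nM.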

Compound 4, half-maximal inhibitory concentration: 18000 nM
For compound 4 the middle estimate is 11-fold (1.02 log units) below the measured one; the whole stated range lies below it.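

In this assay, adding the second trifluoromethyl to the core of compound 3 gives a 4.5-fold higher number from compound 3 to compound 4 (0.65 log units; beyond the scatter), so the change does not carry over from the core of compound 2 in either direction or size: the same change on two cores in this assay, a 2.6-fold lower number (0.42 log units; beyond the scatter) from compound 2 to compound 1 and a 4.5-fold higher number (0.65 log units; beyond the scatter) from compound 3 to compound 4, 12-fold (1.07 log units) apart, beyond the scatter of two such steps

For these two cores, the result of this change therefore cannot be transferred from one to the other. With a single pair on each core, the data do not show which direction is more typical of the series, nor what in the cores accounts for the split.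

From the compounds shown here alone, it remains open whether a nitrile or a chlorine in place of the same hydrogen would split the same way on the two cores. A longer chain in the linker is also untested against this reversal in the compounds shown.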